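Swapping Diallylamino for Benzyl(ethyl)amino on the Side Chain

A few compounds are considered here, and "the series" means these few. Any claim that something is new, unique, unknown or untested is made for them only; others in the source may bear on it.

Compound 1 `C=CCN(CC=C)Cc1c(C(F)(F)F)nc2n(-c3c(C)cc(C)cc3C)c(Cl)cn12` and compound 2 `CCCN(Cc1ccc(Cl)cc1)Cc1c(C(F)(F)F)nc2n(-c3c(C)cc(C)cc3C)c(Cl)cn12` share one core and differ in the group on a saturated chain carbon bound to an aromatic carbon. In an assay on cells for displacement of a labelled ligand from corticotropin-releasing factor receptor 1 (Homo sapiens), with a stated time of 100 min (on this read-out higher numbers stand for weaker inhibition and lower numbers for stronger inhibition), compound 1 gives 13 nM, the lowest of the two numbers recorded here, and compound 2 gives 28 nM, a gap beyond the usual scatter. For the measured compounds named here, no single-change step between measured compounds is available. Compound 3 `CCN(Cc1ccccc1)Cc1c(C(F)(F)F)nc2n(-c3c(C)cc(C)cc3C)c(Cl)cn12` carries benzyl(ethyl)amino in place of diallylamino on a saturated chain carbon bound to an aromatic carbon. A benzyl-bearing amine at this place still gives a low number, since compound 2 with its 28 nM lies close to compound 1, so the change is expected to shift the number only modestly, if at all, toward weaker inhibition. Compound 3 is therefore expected to give 20 nM, with a range from 7 nM to 60 nM. That would mean a step of a 1.5-fold higher number from compound 1 to compound 3 (0.19 log units; within the scatter), expected to stay within or only just beyond the scatter.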

Compound 3, inhibition constant: 350 nM
Beside the measured number, compound 3's estimate is 18-fold (1.24 log units) below it; measured number outside the range, above it.
By their numbers in this assay, from the lowest: compound 1; then compound 2; then compound 3.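

In this assay, putting benzyl(ethyl)amino in place of diallylamino on a saturated chain carbon bound to an aromatic carbon gives a 27-fold higher number from compound 1 to compound 3 (1.43 log units; beyond the scatter), so this place is sensitive to which amine it carries. Compound 2 also carries a benzyl-type amine, but it differs from compound 3 in more than one place, so its value cannot be set against this step as the effect of one change. Nothing measured here gives a reason for the large step.

As far as these compounds go, the change removes both allyl groups and brings in an ethyl group and a benzyl ring at once, so it remains open which of these parts drives the step. Diethylamino or benzyl(allyl)amino at this place would help to separate those parts.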